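The source may hold more compounds than are shown below. What is called first, only, known or untested is meant among the compounds shown, and "the series" means these compounds.

Working notes on the series.

Compound 2 `COc1ccc(F)c(-c2ccc(Cc3ccc(N4C[C@@H](C(F)(F)F)C[C@H]4CC(=O)O)cc3)c(C)c2)c1` has the highest number of the two measured compounds in a functional assay on cells for agonist activity at Free fatty acid receptor 1 (Mus musculus), read by FLIPR and calcium flux, with a stated time of 100 s (a higher number here means that more compound is needed for the effect, a lower number that less compound is needed), where compound 2 gives 2400 nM; the nearest neighbour is compound 1 `Cc1ccccc1Cc1ccc(N2C[C@@H](C(F)(F)F)C[C@H]2CC(=O)O)cc1`, which in this assay gives 710 nM. Among the compounds with values here, the one measured step, a 3.4-fold higher number from compound 1 to compound 2 (0.53 log units; beyond the scatter), concerns 2-fluoro-5-methoxyphenyl in place of hydrogen on an aromatic carbon and says nothing about configuration.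

Compound 3 `COc1ccc(F)c(-c2ccc(Cc3ccc(N4C[C@H](C(F)(F)F)C[C@H]4CC(=O)O)cc3)c(C)c2)c1` differs from compound 2 as follows: the two compounds have the same atoms and bonds and differ only in configuration as drawn: 1 of 2 stereo elements differ; a stereocentre at a saturated ring carbon is drawn S in compound 2 and R in compound 3. Within the data shown here, no measured step bears on a change of this kind, so the size and direction of the effect in this assay cannot be read from the series; the value of compound 2 is the only anchor.

For compound 3 the expected step is a 1.3-fold higher number from compound 2 to compound 3 (0.10 log units; within the scatter), a step that is wide in its uncertainty and may fall on either side. Compound 3 is therefore estimated at 3000 nM in this assay, with a range from 700 nM to 13000 nM.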

Compound 3, half-maximal effective concentration: 1100 nM
Compound 3: the middle estimate sits 2.7-fold (0.44 log units) above what was measured, and the stated range covers the measured number.
By their numbers in this assay, from the lowest: compounds 1 and 3 (each within the scatter of the next); then compound 2.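

A change of configuration alone gives a 2.2-fold lower number from compound 2 to compound 3 (0.34 log units; beyond the scatter) in this assay, the first measured sign in the series that a stereocentre at a saturated ring carbon, drawn S in one compound and R in the other, affects the number. The step can be assigned to that stereocentre alone because nothing else separates the pair: the fact that compounds 2 and 3 differ only in the configuration as drawn. It is modest, and it is read only with the 2-fluoro-5-methoxyphenyl group in place.

On these data alone, whether the same inversion gives a step of like size or direction on compound 1, which lacks that group, remains open. Also open, as far as these compounds go, is whether the step holds when a nitrile stands in place of the trifluoromethyl group.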